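From an Ester to an Acid: Expecting No Gain

The source may report more compounds than this note shows. Statements on the series, on what has been measured and on what is new or still open speak of the compounds shown alone.

Compound 1 `CCCn1c(NC(=O)c2nccc3ccccc23)nc2cc(C(N)=O)cc(OC)c21`, compound 2 `COCCCOc1cc(C(N)=O)cc2nc(NC(=O)c3ccccn3)n(CCCNC(=O)OCc3ccccc3)c12` and compound 3 `CCn1nc(C)cc1C(=O)Nc1nc2cc(C(=O)OC)cnc2n1CCCNC(=O)OC(C)(C)C` were tested in an assay for activation of interferon regulatory factor 3 (Homo sapiens), read by a luciferase reporter, with a stated time of 20 h; on this read-out higher numbers stand for an effect only at larger amounts of compound and lower numbers for an effect already at smaller amounts. Compound 1 gives only a limit of the assay, > 100000 nM. Compound 2 likewise reaches only the limit, > 100000 nM. Compound 3 also stops at the limit, > 100000 nM. Compound 3 therefore stands at the limit of > 100000 nM in this assay, at which 3 of the 3 values shown sit, with no number to set it against the others. Compound 4 `CCn1nc(C)cc1C(=O)Nc1nc2cc(C(=O)O)cnc2n1CCCNC(=O)OC(C)(C)C` differs from compound 3 in one place: hydrogen in place of methyl on an oxygen next to a carbonyl group. Among the compounds with values here, no step between measured compounds exists, so its size is unknown; no move beyond the scatter in this assay is expected. The expected step from compound 3 to compound 4 is a number no higher from compound 3 to compound 4 (the limit leaves the size open). Compound 4 is expected to give 100000 nM, within 30000 nM to 300000 nM.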

Compound 4, half-maximal effective concentration: > 100000 nM
Compound 4: a limit, no number; the forecaster's own chance of this, stated with the estimate: 85%; the middle value sits exactly at the limit.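

The step from compound 3 to compound 4 cannot be read; both values are limits, not numbers. The compounds shown leave open which structure, if any, would give a readable number in this assay, since all stop at one limit: the limit of > 100000 nM in this assay, at which 4 of the 4 values shown sit.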